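The compounds below may be only part of what the source reports. "The series", "measured", "known", "first", "only" and "open" are said of these compounds alone.

Measured so far in an assay on isolated protein for inhibition of Calpain-1 catalytic subunit (Sus scrofa); a higher number here means a weaker inhibitor, a lower number a stronger inhibitor:
compound 1 `O=C(O)/C(S)=C/c1c[nH]c2ccc(I)cc12` gives 90 nM;
compound 3 `O=C(O)/C(S)=C/c1c[nH]c2ccc(Cl)cc12` gives 50 nM;
compound 2 `O=C(O)/C(S)=C/c1cccc(I)c1` gives 23900 nM.

Compound 2 gives the highest of the three numbers; its nearest neighbour is compound 1, and the gap between them is beyond the scatter. How the core of compound 2 differs from the core of compound 1 is not broken down here. Within the core of compound 1, the step of a 1.8-fold lower number from compound 1 to compound 3 (0.26 log units; within the scatter) is chloro in place of iodo on an aromatic carbon.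

Compound 4 `O=C(O)/C(S)=C/c1cccc(Cl)c1` has not yet been measured in this assay; it is chloro in place of iodo on an aromatic carbon. This is the same kind of change as from compound 1 to compound 3, not the same: in compound 1 the place is part of a fused or bridged system of two rings, meta to a fused ring and para to a fused ring, whereas in compound 2 it lies on a six-membered aromatic ring of carbon only, meta to a group of 6 heavy atoms.

For compound 4 a similarly small step is expected, because a 1.8-fold lower number from compound 1 to compound 3 (0.26 log units; within the scatter) lies within the scatter, estimated as a 1.5-fold lower number from compound 2 to compound 4 (0.17 log units; within the scatter). Compound 4 is therefore expected to give about 16000 nM in this assay, within a likely range from 6000 nM to 45000 nM.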

Compound 4, half-maximal inhibitory concentration: 13100 nM
Estimate against measurement, compound 4: 1.2-fold (0.09 log units) above; the range from low to high includes it.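

In this assay, chloro in place of iodo on an aromatic carbon of the six-membered aromatic ring gives a 1.8-fold lower number from compound 2 to compound 4 (0.26 log units; within the scatter), so this change leaves the reading within the scatter on this core. Set beside the earlier case, the change reads alike on both cores: the same change on two cores in this assay, a 1.8-fold lower number (0.26 log units; within the scatter) from compound 1 to compound 3 and a 1.8-fold lower number (0.26 log units; within the scatter) from compound 2 to compound 4, 1.0-fold (0.01 log units) apart, within the scatter of two such steps This shows only that a small step carried over between these two cores with this one pair of halogens; as both steps lie within the scatter, it gives no evidence that either halogen is preferred, and it does not show that the change would stay small on any other core.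

The compounds shown leave open how fluoro, methoxy or an amine at this place would read in this assay, since only iodo and chloro appear there. Also open, from the compounds shown here alone, is whether the small step would persist with an ester or an amide in place of the carboxylic acid.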